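Chloro in place of fluoro in the series

The source may hold more compounds than are shown below. What is called first, only, known or untested is meant among the compounds shown, and "the series" means these compounds.

In a functional assay on MCF7 cells (Homo sapiens) for antiproliferative activity, read by MTT assay, with a stated time of 72 h (a higher number here means a weaker inhibitor, a lower number a stronger inhibitor), compound 3 `COc1ccc(/C=C2/CN(C)/C(=N/c3ccc(F)cc3)S2)cc1` gives 8000 nM. This lies within the scatter of compound 2 `COc1ccc(/C=C2/CN(C)/C(=N/c3ccc(C)cc3)S2)cc1` at 7600 nM, and compound 1 `COc1ccc(/C=C2/CN(C)/C(=N/c3ccc(C(C)(C)C)cc3)S2)cc1` gives the highest number of the three at 28700 nM.

The next change leads to compound 4 `COc1ccc(/C=C2/CN(C)/C(=N/c3ccc(Cl)cc3)S2)cc1`: chloro in place of fluoro on an aromatic carbon. This is chloro in place of fluoro on an aromatic carbon, para to a large group.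

Going by the values given here, three measured steps concern this same place. Two are modest and both remove tert-butyl: a 3.8-fold lower number from compound 1 to compound 2 (0.58 log units; beyond the scatter) and a 3.6-fold lower number from compound 1 to compound 3 (0.55 log units; beyond the scatter). Among the compounds with values here, the closest precedent exchanges methyl for fluoro and stays within the scatter: a 1.1-fold higher number from compound 2 to compound 3 (0.02 log units; within the scatter). Within the data shown here, with only these three compounds, that precedent is thin, and no chloro compound has yet been measured. No step beyond the scatter is therefore expected in this assay, and no direction is favoured.

The estimated change is a 1.1-fold lower number from compound 3 to compound 4 (0.03 log units; within the scatter). For compound 4 the expected value is 7500 nM, with an estimated range from 4000 nM to 14000 nM.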

Compound 4, half-maximal inhibitory concentration: 7600 nM
Compound 4: the middle estimate sits 1.0-fold (0.01 log units) below what was measured; the range from low to high includes it.
By their numbers in this assay, from the lowest: compounds 2, 4 and 3 (each within the scatter of the next); then compound 1.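

In this assay, chloro can now be set beside fluoro and methyl at this place on the ring: a 1.1-fold lower number from compound 3 to compound 4 (0.02 log units; within the scatter), and no change at the digits printed from compound 2 to compound 4 (within the scatter), so the three groups cannot be told apart. The step from tert-butyl to chloro, a 3.8-fold lower number from compound 1 to compound 4 (0.58 log units; beyond the scatter), adds a third modest step of similar size to those to methyl and fluoro, leaving compound 1 as the only one of the four set apart. Nothing available here offers an explanation for either observation.

Still open, on these data alone, is whether an amine, a carboxylic acid or a trifluoromethyl group at this place would stay within the scatter of compound 4. Also open, as far as these compounds go, is whether isopropyl would sit with compound 1 or with the other three compounds.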